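Working notes: chloro in place of methyl, compound 4

A few compounds are considered here, and "the series" means these few. Any claim that something is new, unique, unknown or untested is made for them only; others in the source may bear on it.

Values in a functional assay on MDA-MB-231 cells (Homo sapiens) for antiproliferative activity, with a stated time of 5 days; a lower number here means a stronger inhibitor, a higher number a weaker inhibitor:
- compound 1 `COc1ccc(-n2nc(-c3ccc4ccccc4c3)nc2N2C(=O)COC23C=CC(=O)C=C3)cc1`: 60 nM
- compound 2 `Cc1ccc(-n2nc(-c3ccc4ccccc4c3)nc2N2C(=O)COC23C=CC(=O)C=C3)cc1`: 30 nM
- compound 3 `Cc1ccc(-n2nc(-c3ccc4ccccc4c3)nc2N2C(=O)C(C)OC23C=CC(=O)C=C3)cc1`: 100 nM

Compound 2 stands at 30 nM, which cannot be separated from compound 1 but is clear of compound 3.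

The unmeasured compound 4 `O=C1C=CC2(C=C1)OCC(=O)N2c1nc(-c2ccc3ccccc3c2)nn1-c1ccc(Cl)cc1` keeps the core of compound 2 and alters one group: chloro in place of methyl on an aromatic carbon. This is chloro in place of methyl on an aromatic carbon, or 4-methylphenyl to 4-chlorophenyl.

The closest evidence is the change on that same aromatic carbon, methyl in place of methoxy, which gave a 2.0-fold lower number from compound 1 to compound 2 (0.30 log units; within the scatter). The other measured change, methyl in place of hydrogen on a saturated ring carbon, gave a 3.3-fold higher number from compound 2 to compound 3 (0.52 log units; beyond the scatter). It lies elsewhere in the molecule and bears only weakly on compound 4. For the measured compounds named here, no chloro compound has been measured, so the evidence is indirect.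

Going by the values given here, on the single step at this carbon, no change beyond the scatter is expected in this assay, and no direction is favoured. The expected result is a 1.2-fold higher number from compound 2 to compound 4 (0.07 log units; within the scatter). Compound 4 is estimated at 35 nM, with an expected range of 15 nM to 80 nM.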

Compound 4, half-maximal inhibitory concentration: 70 nM
The estimate for compound 4 lay 2.0-fold (0.30 log units) below the measured number; the measured number falls inside the stated range.
By their numbers in this assay, from the lowest: compounds 2, 1, 4 and 3 (each within the scatter of the next, the first and the last beyond it).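

In this assay, for the compounds shown here, the step of a 2.3-fold higher number from compound 2 to compound 4 (0.37 log units; beyond the scatter) is the first change at this aromatic carbon to pass beyond the scatter, although it remains modest. The step of a 1.2-fold higher number from compound 1 to compound 4 (0.07 log units; within the scatter) stays within the scatter, as does the earlier change from methoxy to methyl, so of the three groups at this carbon only the methyl and chloro pair can be separated, and methoxy cannot be separated from either. Nothing available accounts for the separation between methyl and chloro.

The compounds shown leave open how this carbon responds to a group of a different kind, such as an amine, a carboxylic acid or a longer alkyl chain, since the range so far covers only methyl, methoxy and chloro. Going by these compounds alone, they also leave open whether the methyl on the saturated ring carbon, seen only with the 4-methylphenyl group in compound 3, has a similar effect alongside 4-chlorophenyl.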